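Swapping the Benzyl Substituent in an Adenosine Receptor Series

A few compounds are considered here, and "the series" means these few. Any claim that something is new, unique, unknown or untested is made for them only; others in the source may bear on it.

Measured compounds:
compound 1, `O[C@@H]1[C@H](O)[C@@H]2C[C@@H]2[C@H]1n1cnc2c(NCCCF)nc(Cl)nc21`, 32.4 nM
compound 2, `CCOc1ccccc1CNc1nc(Cl)nc2c1ncn2[C@H]1[C@H](O)[C@H](O)[C@@H]2C[C@@H]21`, 15.2 nM

Both compounds were tested in an assay on CHO cells for displacement of a labelled ligand from adenosine receptor A3 (Homo sapiens), with a stated time of 60 min; on this read-out lower numbers stand for stronger inhibition and higher numbers for weaker inhibition. Of the two numbers shown, compound 2 holds the lower one, and its nearest neighbour is compound 1, which differs from it by a 2.1-fold lower number from compound 1 to compound 2 (0.33 log units; beyond the scatter), a modest step that nonetheless lies beyond the scatter of repeated measurements.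

Compound 3, `COc1ccc(F)c(F)c1CNc1nc(Cl)nc2c1ncn2[C@H]1[C@H](O)[C@H](O)[C@@H]2C[C@@H]21`, has not yet been measured. It is derived from compound 2 by a single change: 2,3-difluoro-6-methoxyphenyl in place of 2-ethoxyphenyl on a saturated chain carbon bound to a nitrogen on an aromatic ring. Within the data shown here, the only measured step available, that from compound 1 to compound 2, replaces a short fluorinated chain with an aromatic ring on that same carbon; it does not compare one aromatic ring against another, so it offers no direct guide to the present change. Without a comparable step to lean on, the expectation is that compound 3 stays close to compound 2 in this assay, with a step of about a 1.0-fold lower number from compound 2 to compound 3 (0.01 log units; within the scatter), not beyond the scatter. Compound 3 is therefore estimated at 15 nM, with a range from 5 nM to 45 nM.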

Compound 3, inhibition constant: 83.2 nM
Estimate against measurement, compound 3: 5.5-fold (0.74 log units) below, and the stated range ends below it.
By their numbers in this assay, from the lowest: compound 2; then compound 1; then compound 3.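

In this assay the aromatic ring on this saturated chain carbon proves not to be interchangeable: replacing 2-ethoxyphenyl with 2,3-difluoro-6-methoxyphenyl gives a 5.5-fold higher number from compound 2 to compound 3 (0.74 log units; beyond the scatter), so the substituents on the ring matter at this position, which the earlier step from a fluorinated chain to a ring could not reveal. An aromatic ring at this place also does not bring a lower number by itself, since replacing 2-fluoroethyl with 2,3-difluoro-6-methoxyphenyl gives a 2.6-fold higher number from compound 1 to compound 3 (0.41 log units; beyond the scatter), the opposite direction to the step that introduced 2-ethoxyphenyl. Nothing shown here bears on why the number rises with this change.

The new ring differs from the old one in both its ether group and its fluorines, so the compounds shown cannot assign the rise to either feature alone. From the compounds shown here alone, how a plain phenyl ring, a pyridine ring or a ring carrying chlorine in place of fluorine would behave on this carbon remains open, as does the behaviour of all these compounds at other adenosine receptors.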